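The source may report more compounds than this note shows. Statements on the series, on what has been measured and on what is new or still open speak of the compounds shown alone.

The measured compounds:
Compound 1 `CC(O)c1cn(Cc2cc(=O)oc3cc(O)ccc23)nn1` — in a functional assay on A549 cells (Homo sapiens) for inhibition, read by MTT assay, with a stated time of 72 h (a higher number here means a weaker inhibitor, a lower number a stronger inhibitor), compound 1 gives > 100000 nM, which is a limit of the assay.
Compound 2 `O=c1cc(Cn2cc(CCCCO)nn2)c2ccc(O)cc2o1` — in this assay compound 2 gives > 100000 nM, also a limit of the assay.
Compound 3 `CC(C)(C)c1cn(Cc2cc(=O)oc3cc(O)ccc23)nn1` — in this assay compound 3 gives 67600 nM.

Going by the values given here, compound 3 therefore holds the only number recorded, the other two values sitting at the limit of > 100000 nM in this assay, at which 2 of the 3 values shown sit. Compound 4 `CCCCCCCCc1cn(Cc2cc(=O)oc3cc(O)ccc23)nn1` differs from compound 3 by octyl in place of tert-butyl on an aromatic carbon. The measured steps bearing on this change both end at compound 3 and start from a limit: an at least 1.4-fold lower number from compound 1 to compound 3 (0.17 log units; that floor lies within the scatter) and an at least 1.4-fold lower number from compound 2 to compound 3 (0.17 log units; that floor lies within the scatter); the remaining step, a step that the two limits leave unreadable from compound 1 to compound 2, gives nothing further. None fixes a size beyond the scatter, so the direction in this assay is taken cautiously, towards a somewhat lower number. For compound 4 the expected step is a 2.3-fold lower number from compound 3 to compound 4 (0.35 log units; beyond the scatter). Compound 4 is estimated at 30000 nM, within 8000 nM to 120000 nM.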

Compound 4, half-maximal inhibitory concentration: 46000 nM
For compound 4 the middle estimate is 1.5-fold (0.19 log units) below the measured one, within the range that was stated.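

In this assay, octyl in place of tert-butyl on this aromatic carbon gives a 1.5-fold lower number from compound 3 to compound 4 (0.17 log units; within the scatter), so the two groups cannot be told apart here. Set against the chains that carry a hydroxy group, octyl gives the first steps beyond the scatter, an at least 2.1-fold lower number from compound 2 to compound 4 (0.33 log units; beyond the scatter) and an at least 2.1-fold lower number from compound 1 to compound 4 (0.33 log units; beyond the scatter). Both steps start from a limit of the assay, not a number: the limit of > 100000 nM in this assay, at which 2 of the 4 values shown sit.

The compounds shown leave open how an amine, a carboxylic acid or a chain longer than octyl at this position would read in this assay.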